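Piperidin-2-yl Gives Way to Bromophenyl on a Shared Core

The source may hold more compounds than are shown below. What is called first, only, known or untested is meant among the compounds shown, and "the series" means these compounds.

Of the compounds shown here, three have so far been measured in an assay for inhibition of Tryptophan 2,3-dioxygenase (Homo sapiens), with stated times of 10 min and 60 min, tested at 100 uM; on this read-out lower numbers stand for a weaker effect and higher numbers for a stronger effect at the one concentration tested. Compound 1 `O=C1NCc2c(NCc3ccccc3[N+](=O)[O-])cccc21` gives 29%, compound 3 `O=[N+]([O-])c1ccc2[nH]c(CNc3cc(C(F)(F)F)cc4[nH]ncc34)cc2c1` gives 69%, and compound 2 `FC(F)(F)c1cc(NC[C@H]2CCCCN2)c2cn[nH]c2c1` gives 90%, the highest of the three numbers; its nearest neighbour, compound 3, sits beyond the scatter below it, and compound 1 sits further below still. No two of these compounds differ in only one place, so no single step between measured compounds can be read off.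

Compound 4 `FC(F)(F)c1cc(NCc2cccc(Br)c2)c2cn[nH]c2c1` has not yet been measured. It differs from compound 2 in one place: 3-bromophenyl in place of piperidin-2-yl on a saturated chain carbon bound to a nitrogen on an aromatic ring. The group that leaves brings a hydrogen-bond donor and an acceptor, and the 3-bromophenyl that enters brings neither. The step from compound 2 to compound 4 is expected to be a drop beyond the scatter, a number 25 percentage points lower from compound 2 to compound 4 (beyond the scatter), because compound 3, which also lacks a piperidin-2-yl, gives 69%. Compound 4 is therefore estimated at 65%, with a range from 35% to 90%.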

Compound 4, a percentage reported as inhibition, at one concentration (the size of the read-out at that concentration, not a potency): 84%
The estimate for compound 4 lay 19 percentage points below the measured number; the range from low to high includes it.
By their numbers in this assay, from the lowest: compound 1; then compound 3; then compounds 4 and 2 (each within the scatter of the next).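

At the place on a saturated chain carbon bound to a nitrogen on an aromatic ring, the shared core keeps its read-out in this assay when 3-bromophenyl replaces piperidin-2-yl (a number 6 percentage points lower from compound 2 to compound 4 (within the scatter)). For this pair, then, a six-membered aromatic ring of carbon only, with 0 hydrogen-bond donors and 0 hydrogen-bond acceptors, reads the same within the scatter as the non-aromatic ring with its donor, acceptor and defined stereocentre. Nothing available explains why the two groups read alike.

Going by these compounds, whether an amine or a carboxylic acid on the phenyl ring, or a longer chain leading to it, would keep the read-out at this place remains open. Also open, on these data alone, is whether compound 2 and compound 4 would read alike at other concentrations, since the single concentration gives no potency.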